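This account rests on a few compounds, and the source may have more. Where it says the series, first, only, none or still open, it means among the compounds named here.

Compound 1 `O=C1C=COC(/C=C/c2ccccc2)C1` is the simplest member of this small set. In a functional assay on HT-29 cells (Homo sapiens) for inhibition, read by sulforhodamine B assay, with a stated time of 48 h (a higher number here means a weaker inhibitor of growth, a lower number a stronger inhibitor of growth), compound 1 gives 124 uM. Compound 2 `COc1ccc(/C=C/C2CC(=O)C=CO2)cc1` carries one change, (methoxy in place of hydrogen on an aromatic carbon), and in this assay compound 2 gives 204 uM, so the step is a 1.6-fold higher number from compound 1 to compound 2 (0.22 log units; within the scatter). Compound 3 `COc1cc(/C=C/C2CC=CC(=O)N2)cc(OC)c1` is built on a different core; how its core differs from that of compound 1 is not broken down here. In this assay compound 3 gives 197 uM. Compound 4 `COc1cc(/C=C/C2CC=CC(=O)N2)cc(OC)c1OC`, not yet measured, differs from compound 3 by methoxy in place of hydrogen on an aromatic carbon, the same kind of change as before, though here the new group sits ortho to two methoxy groups. Resting on the earlier step of a 1.6-fold higher number from compound 1 to compound 2 (0.22 log units; within the scatter), the step expected for compound 4 is a 1.3-fold higher number from compound 3 to compound 4 (0.12 log units; within the scatter). The value expected for compound 4 is 260 uM, estimated to lie between 120 uM and 600 uM.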

Compound 4, concentration for growth inhibition (reported as GI): > 864 uM
Compound 4: only a limit was reported (the forecaster's own chance of this, stated with the estimate: 15%); middle value at least 3.3-fold (0.52 log units) from the limit.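

In this assay, methoxy in place of hydrogen on an aromatic carbon gives an at least 4.3-fold higher number from compound 3 to compound 4 (0.64 log units; beyond the scatter). As far as these compounds go, compound 4 is reported only as a limit, > 864 uM, so the full size of this step remains unknown. This does not show whether the change behaves the same or differently when carried from one core to the other: the same change on two cores in this assay, a 1.6-fold higher number (0.22 log units; within the scatter) from compound 1 to compound 2 and an at least 4.3-fold higher number (0.64 log units; beyond the scatter) from compound 3 to compound 4; the limit leaves it open whether they differ

The compounds shown leave open how a methoxy group ortho to two methoxy groups would behave on the core of compound 1. Also open, from the compounds shown here alone, is whether a hydroxyl group or a chlorine atom in that same place would give a measurable value on the core of compound 3.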